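This account rests on a few compounds, and the source may have more. Where it says the series, first, only, none or still open, it means among the compounds named here.

Measured compounds:
compound 1, `COC(=O)/C=C/c1cccc(N(Cc2ccccc2Br)C(=O)C2CCCCC2)c1`: > 1000 nM
compound 2, `COC(=O)/C=C/c1cccc(N(Cc2ccc(Br)cc2)C(=O)C2CCCCC2)c1`: > 1000 nM

Compound 1 carries 2-bromophenyl on the saturated chain carbon bound to the amide-type nitrogen; in an assay on isolated protein with Bile acid receptor (Homo sapiens) as the target (on this read-out lower numbers stand for an effect already at smaller amounts and higher numbers for an effect only at larger amounts of compound), compound 1 returns > 1000 nM, which is a limit of the assay and not a number. Compound 2 carries 4-bromophenyl in the same place; in this assay compound 2 likewise returns > 1000 nM, again a limit and not a number. Among the compounds with values here, the one step in hand, a step that the two limits leave unreadable from compound 1 to compound 2, cannot be sized: both of its ends sit at the limit of > 1000 nM in this assay, at which 2 of the 2 values shown sit. Compound 2 thus stands at the limit, with no number of its own on this read-out.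

Compound 3, `COC(=O)/C=C/c1cccc(N(Cc2ccc(-c3ccc(OC(F)(F)F)cc3)cc2)C(=O)C2CCCCC2)c1`, differs from compound 2 in one place: 4-(trifluoromethoxy)phenyl in place of bromo on an aromatic carbon. Within the data shown here, no measured step covers a change of this kind; the only step available, a step that the two limits leave unreadable from compound 1 to compound 2, exchanges one bromophenyl for another and is unreadable, so it offers neither size nor direction to carry over. With compound 2 at a limit, any expectation rests on the structural change alone. The step of an at least 1.6-fold lower number from compound 2 to compound 3 (0.22 log units; that floor lies within the scatter) is an expectation only. Compound 3 is estimated at 600 nM, within 100 nM to 3000 nM, with a real chance that the assay again returns only a limit.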

Compound 3, half-maximal effective concentration: 264 nM
Compound 3: middle estimate off by 2.3-fold (0.36 log units), on the high side; the range from low to high includes it.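

In this assay, within the data shown here, 4-(trifluoromethoxy)phenyl in place of bromo on this aromatic carbon gives an at least 3.7-fold lower number from compound 2 to compound 3 (0.57 log units; beyond the scatter), the only step that can be read so far, and it shows that this position accepts a much larger group with a real gain on this read-out. Compound 2 gives > 1000 nM, which is a limit and not a number, so the size of this step is only a floor and the true difference may be larger. The entering group brings a six-membered aromatic ring of carbon only and a hydrogen-bond acceptor together, so this single step cannot show which part of the group carries the change.

From the compounds shown here alone, whether an unsubstituted phenyl, a 4-methoxyphenyl or a 4-aminophenyl at this position would keep the gain stays open, as does the effect of a carboxylic acid in place of the methyl ester. The step between the two bromophenyl compounds cannot be read, so nothing can yet be said about where the large group is best placed, and the series still rests heavily on limits: the limit of > 1000 nM in this assay, at which 2 of the 3 values shown sit.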